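The compounds below may be only part of what the source reports. "The series", "measured", "known", "first", "only" and "open" are said of these compounds alone.

Compound 1 `C[C@@H](Cn1ccc(-c2ccc(C#N)c(Cl)c2)n1)NC(=O)c1ccccc1`, compound 2 `C[C@@H](Cn1ccc(-c2ccc(C#N)c(Cl)c2)n1)Nc1cncnc1` and compound 3 `C[C@@H](Cn1ccc(-c2ccc(C#N)c(Cl)c2)n1)Nc1nccc(Cl)n1` share one core and differ in a single group. In an ADME assay on L02 cells (Homo sapiens) for cytotoxicity, read by CCK-8 assay, with a stated time of 6 days (on this read-out higher numbers stand for weaker inhibition and lower numbers for stronger inhibition), compound 1 gives "not determined" (no result reported) and so offers no number for comparison. Compound 2 gives > 30000 nM in this assay as a limit of the assay and not a number. Compound 3 gives "not determined" (no result reported) in this assay as well, so it stands without a number of its own. The compound still to be measured is compound 4 `C[C@@H](Cn1ccc(-c2ccc(C#N)c(Cl)c2)n1)Nc1ncnc2nc[nH]c12`. The structural change is a group of 9 heavy atoms (5 carbon, 4 nitrogen; one five-membered aromatic ring with 2 hetero atoms, one six-membered aromatic ring with 2 hetero atoms) in place of a group of 7 heavy atoms (4 carbon, 2 nitrogen, 1 chlorine; one six-membered aromatic ring with 2 hetero atoms), on an amine nitrogen and it takes the 4-chloropyrimidin-2-yl group away from the amine nitrogen. No measured step exists among these compounds to show how large such a change might be. For the measured compounds named here, for compound 2 the one reading is > 30000 nM and that limit is the only guide, so in this assay no step beyond the usual scatter is expected and inhibition should stay weak. Compound 4 is estimated at 30000 nM with an expected range of 12000 nM to 60000 nM for its reading.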

Compound 4, half-maximal inhibitory concentration: 27900 nM
Estimate against measurement, compound 4: 1.1-fold (0.03 log units) above, and the stated range covers the measured number.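

In this assay compound 4 gives 27900 nM, the first actual number among these compounds for a group on this amine nitrogen. With the group of 9 heavy atoms, which carries a five-membered and a six-membered aromatic ring, the comparison reads an at least 1.0-fold lower number from compound 2 to compound 4 (0.03 log units; that floor lies within the scatter), so this larger group shows no step beyond the scatter, though that figure is only a floor. Compound 2 remains a limit of the assay and not a number: the limit of > 30000 nM in this assay, at which 1 of the 4 values shown sits.

Steps involving compound 1 and compound 3 cannot be read, so the benzoyl amide and the 4-chloropyrimidin-2-yl group stay unplaced beside compound 4. Also open, on these data alone, is whether a simpler group on this amine nitrogen, such as a carboxylic acid or a longer chain ending in an amine, would give a clearly different reading.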